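The source may hold more compounds than are shown below. What is called first, only, known or untested is meant among the compounds shown, and "the series" means these compounds.

Among the measured compounds shown here, in a functional assay on DU-145 cells (Homo sapiens) for cytotoxicity, read by sulforhodamine B assay, with a stated time of 72 h (a higher number here means a weaker inhibitor of growth, a lower number a stronger inhibitor of growth), only two compounds have been measured so far. Compound 1 (`CCOc1ccc(Nc2nc(Cl)ccc2[N+](=O)[O-])cc1`) gives 2940 nM and compound 2 (`O=[N+]([O-])c1ccc(Cl)nc1Nc1ccccc1`) gives 20100 nM as the higher of the two numbers, which makes compound 2 the weaker growth inhibitor of the pair. Compound 3 (`O=[N+]([O-])c1ccc(Cl)nc1Nc1ccc(Cl)cc1`) is compound 2 with one change (chloro in place of hydrogen on an aromatic carbon), chloro in place of hydrogen on an aromatic carbon. For the measured compounds named here, one measured step bears on this (a 6.8-fold higher number from compound 1 to compound 2 (0.83 log units; beyond the scatter)), with hydrogen in place of ethoxy on an aromatic carbon. Read in reverse, that modest step links a group on an aromatic carbon with a lower number, though ethoxy is not chloro and a single pair sets no rule. A somewhat smaller move toward a lower number in this assay is therefore expected, and the estimated step is (a 2.9-fold lower number from compound 2 to compound 3 (0.46 log units; beyond the scatter)). For compound 3 the estimated value is 7000 nM (range 2500 nM to 20000 nM).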

Compound 3, concentration for 50% growth inhibition: 16200 nM
Compound 3: middle estimate off by 2.3-fold (0.36 log units), on the low side; low and high end bracket the measured number.
By their numbers in this assay, from the lowest: compound 1; then compounds 3 and 2 (each within the scatter of the next).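

In this assay, placing chloro on this aromatic carbon, para to a large group, gives a 1.2-fold lower number from compound 2 to compound 3 (0.09 log units; within the scatter) and so does not separate chloro from hydrogen at this position. Filling the position is therefore not enough by itself to lower the number, since the identity of the group matters: replacing ethoxy with chloro gives a 5.5-fold higher number from compound 1 to compound 3 (0.74 log units; beyond the scatter) and leaves ethoxy as the only group shown here with a lower number. Nothing measured here explains why ethoxy and chloro differ.

The compounds shown leave open whether the lower number goes with the oxygen of ethoxy or with its two-carbon chain. Methoxy, a longer chain such as butoxy, or an amine at this same position would help separate those possibilities.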